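The source may hold more compounds than are shown below. What is called first, only, known or untested is meant among the compounds shown, and "the series" means these compounds.

Compound 2 `CC(=O)N1CCc2c(sc(NC(=O)c3ccc(OCc4ccccc4)cc3)c2C(N)=O)C1` stands lowest of the two numbers in an ADME assay on RAW264.7 cells (Mus musculus) for cytotoxicity, read by MTT assay, with a stated time of 48 h, tested at 50 uM (a lower number here means less inhibition, a higher number more inhibition at the concentration tested (going by the name of the read-out)), where compound 2 gives 11.6%. Compound 1 `NC(=O)c1c(NC(=O)c2ccc(OCc3ccccc3)cc2)sc2c1CCN(C(=O)c1ccccc1)C2` in this assay gives 13.7%, and the step of a number 2.1 percentage points lower from compound 1 to compound 2 (within the scatter) shows that exchanging methyl for phenyl on a carbonyl carbon changed nothing of note. Compound 3 `CN1CCc2c(sc(NC(=O)c3ccc(OCc4ccccc4)cc3)c2C(N)=O)C1` differs from compound 2 by methyl in place of acetyl on an amine nitrogen in a ring. For the measured compounds named here, no measured step touches this position, so no change beyond the scatter is expected, as a number 0.4 percentage points higher from compound 2 to compound 3 (within the scatter) says. For compound 3 the expected value in this assay is 12%, within 4% to 22%.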

Compound 3, a percentage reported as inhibition, at one concentration (the size of the read-out at that concentration, not a potency): 37.6%
The estimate for compound 3 lay 25.6 percentage points below the measured number; measured number above the stated range.
By their numbers in this assay, from the lowest: compounds 2 and 1 (each within the scatter of the next); then compound 3.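

In this assay the amine nitrogen in a ring proved sensitive to what it carries, which the swap of benzoyl for acetyl had not shown: methyl in place of acetyl gives (a number 26 percentage points higher from compound 2 to compound 3 (beyond the scatter)) and methyl in place of benzoyl gives (a number 23.9 percentage points higher from compound 1 to compound 3 (beyond the scatter)). Compound 1 and compound 2, both with a carbonyl on this nitrogen, stay within the scatter of each other, and only compound 3, without that carbonyl, stands apart. No measurement at hand explains this step.
The compounds shown leave open whether a benzyl group or a longer chain on this nitrogen, or a plain hydrogen there, would stand with compound 3 or with compound 2.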